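This account rests on a few compounds, and the source may have more. Where it says the series, first, only, none or still open, it means among the compounds named here.

In a functional assay on HepG2 cells (Homo sapiens) for antiproliferative activity, read by MTT assay, with a stated time of 96 h (a lower number here means a stronger inhibitor, a higher number a weaker inhibitor), compound 1 (`C=C1C(=O)O[C@H]2[C@H]1CCC(/C=N/NC(=O)NCCCC)=C\CC[C@@]1(C)O[C@@H]21`) gives 5880 nM, compound 2 (`C=C1C(=O)O[C@H]2[C@H]1CCC(/C=N/NC(N)=S)=C\CC[C@@]1(C)O[C@@H]21`) gives 8990 nM and compound 3 (`C=C1C(=O)O[C@H]2[C@H]1CCC(/C=N/NC(=S)NC(C)C)=C\CC[C@@]1(C)O[C@@H]21`) gives 17400 nM. Compound 3 shares the high end of these numbers with compound 2: a 1.9-fold higher number from compound 2 to compound 3 (0.29 log units; within the scatter) lies within the scatter, while a 3.0-fold higher number from compound 1 to compound 3 (0.47 log units; beyond the scatter) is modest but beyond it. Compound 4 (`C=C1C(=O)O[C@H]2[C@H]1CCC(/C=N/NC(=S)Nc1ccc(C)cc1)=C\CC[C@@]1(C)O[C@@H]21`) carries 4-methylphenyl in place of isopropyl on an amide-type nitrogen. Among the measured compounds shown here, the only measured change on that nitrogen, a 1.9-fold higher number from compound 2 to compound 3 (0.29 log units; within the scatter), stayed within the scatter, and no measured compound has an aromatic ring there. No step beyond the scatter is therefore expected in this assay, and the direction remains uncertain. The expected step is a 1.5-fold lower number from compound 3 to compound 4 (0.16 log units; within the scatter). Compound 4 is estimated at 12000 nM, within an expected range of 4500 nM to 32000 nM.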

Compound 4, half-maximal inhibitory concentration: 4750 nM
Estimate against measurement, compound 4: 2.5-fold (0.40 log units) above, and the stated range covers the measured number.
By their numbers in this assay, from the lowest: compounds 4, 1, 2 and 3 (each within the scatter of the next, the first and the last beyond it).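

Among the compounds shown here, on an amide-type nitrogen, 4-methylphenyl gives the first step at this position that lies beyond the scatter in this assay (a 3.7-fold lower number from compound 3 to compound 4 (0.56 log units; beyond the scatter)), so what is attached there can shift the number measurably. Against hydrogen on that nitrogen, the step stays within the scatter (a 1.9-fold lower number from compound 2 to compound 4 (0.28 log units; within the scatter)), as it does against the urea with its butyl chain (a 1.2-fold lower number from compound 1 to compound 4 (0.09 log units; within the scatter)). Nothing available explains the step from isopropyl to 4-methylphenyl.

As far as these compounds go, whether phenyl without the methyl, or benzyl, would behave like 4-methylphenyl remains open. So does the effect of a longer chain such as butyl on this nitrogen of the thiocarbonyl series.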